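Moving the ring substituent again on a thiophene sulfonylurea

This account rests on a few compounds, and the source may have more. Where it says the series, first, only, none or still open, it means among the compounds named here.

Two compounds share a sulfonylurea linking a chlorophenyl group to a thiophene, and have been tested in a functional assay on the whole organism (6C3HED cells, Mus musculus) for inhibition, at a dose of 150 mg/kg by the oral route; on this read-out lower numbers stand for less inhibition and higher numbers for more inhibition at the one dose given (going by the name of the read-out). Compound 1 `CCc1ccc(S(=O)(=O)NC(=O)Nc2ccc(Cl)cc2)s1` carries a 5-ethylthiophen-2-yl group on the sulfonyl sulfur, and in this assay compound 1 gives 57%. Compound 2 `CCc1ccsc1S(=O)(=O)NC(=O)Nc1ccc(Cl)cc1` carries a 3-ethylthiophen-2-yl group instead, and in this assay compound 2 gives 21%. Compound 2 therefore stands lowest of the two numbers measured; the change a number 36 percentage points lower from compound 1 to compound 2 (beyond the scatter) shows that simply moving the ethyl group around the thiophene ring made a large difference.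

Compound 3 `COc1csc(S(=O)(=O)NC(=O)Nc2ccc(Cl)cc2)c1` changes the thiophene substituent again: 4-methoxythiophen-2-yl in place of 3-ethylthiophen-2-yl on a sulfonyl sulfur. For the measured compounds named here, the only measured step that bears on this, the one from compound 1 to compound 2, shows that a new substitution pattern on this ring can shift this assay by a large amount, but it gives no guide to the direction for a methoxy group at a new position. Because of a number 36 percentage points lower from compound 1 to compound 2 (beyond the scatter) a sizeable step in either direction is plausible, so the estimate for compound 3 is 35%, with a wide range from 10% to 65%, meaning an expected step of a number 14 percentage points higher from compound 2 to compound 3 (beyond the scatter).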

Compound 3, a percentage reported as inhibition, in the whole organism at one dose (the size of the read-out at that dose, not a potency): 36%
Compound 3: middle estimate off by 1 percentage points, on the low side, and the stated range covers the measured number.
By their numbers in this assay, from the lowest: compound 2; then compound 3; then compound 1.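

In this assay, the 4-methoxythiophen-2-yl group on the sulfonyl sulfur gives a level of inhibition distinct from that of either ethyl-substituted group. Replacing the 3-ethylthiophen-2-yl group recovers part of the lost inhibition (a number 15 percentage points higher from compound 2 to compound 3 (beyond the scatter)), while the comparison with the 5-ethylthiophen-2-yl group shows that this recovery is incomplete (a number 21 percentage points lower from compound 1 to compound 3 (beyond the scatter)). Compound 1 therefore still gives the most inhibition of the three, and this thiophene position now shows three separate levels rather than two, with no explanation for the differences available from supporting measurements.

The new step changes both the group and its place on the ring, and the count of hydrogen-bond acceptors goes from 1 to 2, so the compounds shown cannot separate the effect of exchanging ethyl for methoxy from that of moving the substituent. They also leave open how an amine, a carboxylic acid or a longer chain on the thiophene would behave in this assay, and whether any such group could match or pass compound 1 at this single oral dose.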